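Methoxy on the Phenylpiperazine of a Triazole Chalcone

The compounds below may be only part of what the source reports. "The series", "measured", "known", "first", "only" and "open" are said of these compounds alone.

Compound 1 `CCCCCCCCCCn1cc(/C=C/C(=O)c2ccc(NC(=O)CN3CCN(c4ccccc4)CC3)cc2)nn1` was examined in a functional assay on MCF7 cells (Homo sapiens) for inhibition, read by MTT assay; on this read-out higher numbers stand for weaker inhibition and lower numbers for stronger inhibition. In this assay compound 1 gives > 100000 nM, which is a limit of the assay and not a number. Compound 2 `CCCCCCCCCCn1cc(/C=C/C(=O)c2ccc(NC(=O)CBr)cc2)nn1` in this assay gives 9760 nM; the step of an at least 10-fold lower number from compound 1 to compound 2 (1.01 log units; beyond the scatter) is the only measured one, and it concerns a different part of the molecule. Compound 3 `CCCCCCCCCCn1cc(/C=C/C(=O)c2ccc(NC(=O)CN3CCN(c4ccccc4OC)CC3)cc2)nn1` differs from compound 1 by methoxy in place of hydrogen on an aromatic carbon. Among the measured compounds shown here, no measured step touches that position, so for compound 3 no change beyond the scatter is expected, a number no higher from compound 1 to compound 3 (the limit leaves the size open). Compound 3 is estimated at 100000 nM, between 30000 nM and 300000 nM, most likely again only a limit.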

Compound 3, half-maximal inhibitory concentration: 44800 nM
The estimate for compound 3 lay 2.2-fold (0.35 log units) above the measured number; the range from low to high includes it.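

In this assay, among the compounds shown here, methoxy in place of hydrogen on an aromatic carbon, ortho to a large group, is the first change on the phenyl of the phenylpiperazine with a measured outcome, and it gives an at least 2.2-fold lower number from compound 1 to compound 3 (0.34 log units; beyond the scatter) as its result. The value of compound 1 is a limit of the assay, so the step fixes only a minimum size: the limit of > 100000 nM in this assay, at which 1 of the 3 values shown sits.

Left open is whether an ethoxy, a hydroxy or a fluoro on the same carbon would give a similar number. Also open, going by these compounds, is whether methoxy elsewhere on that phenyl ring would do the same.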